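Ring stereochemistry in a cyclic peroxide acid series

The source may report more compounds than this note shows. Statements on the series, on what has been measured and on what is new or still open speak of the compounds shown alone.

Measured compounds:
compound 1 `C=C1CCCC(C)(C)C1CC[C@]1(C)CC[C@@H]([C@@H](C)C(=O)O)OO1` gives 5730 nM
compound 2 `CC1=C(CC/C(C)=C/CC[C@@]2(C)CC[C@@H]([C@H](C)C(=O)O)OO2)C(C)(C)CCC1` gives > 100000 nM
compound 3 `C=C1CCCC(C)(C)C1CC[C@@]1(C)CC[C@H]([C@@H](C)C(=O)O)OO1` is not yet measured

For the measured compounds named here, in a functional assay on KM12 cells (Homo sapiens) for inhibition (a higher number here means a weaker inhibitor of growth, a lower number a stronger inhibitor of growth), compound 1 gives 5730 nM and is the only compound with a numerical result. Compound 2 gives > 100000 nM, which is a limit of the assay and not a number; it sits at the limit of > 100000 nM in this assay, at which 1 of the 2 values shown sits. Going by the values given here, no pair of measured compounds differs in only one place, so no measured step is available to calibrate what a change of this kind does. Compound 3 differs from compound 1 in that (the two compounds have the same atoms and bonds; at least one stereo element is drawn with a configuration in one of them and without one in the other: 2 of 4 stereo elements differ; a stereocentre at a saturated ring carbon is drawn R in compound 1 and S in compound 3; a stereocentre at a saturated ring carbon is drawn S in compound 1 and R in compound 3). Among the compounds with values here, with the same atoms and bonds and only two ring stereocentres inverted, a step in this assay of modest size is expected, direction uncertain, and it may well stay within the scatter. Compound 3 is estimated at 9000 nM, range 1500 nM to 60000 nM, a step of a 1.6-fold higher number from compound 1 to compound 3 (0.20 log units; within the scatter) expected.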

Compound 3, concentration for 50% growth inhibition: 4820 nM
Estimate against measurement, compound 3: 1.9-fold (0.27 log units) above; the range from low to high includes it.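

For the compounds shown here, with both saturated ring stereocentres inverted, this assay gives the first measured step (a 1.2-fold lower number from compound 1 to compound 3 (0.08 log units; within the scatter)). For this one pair, the read-out therefore does not separate the two drawn arrangements at these ring carbons, although the shared side chain and the rest of the core stay unchanged. The comparison is still not one between two fully defined structures, and the reading of this pair should carry that qualification: the fact that one of compounds 1 and 3 is drawn with a defined configuration and the other without, at the place where they differ.

As far as these compounds go, it remains open whether either ring stereocentre inverted alone would give a result like that of the double inversion. From the compounds shown here alone, it is also open whether the same lack of separation would hold with the carboxylic acid replaced by a methyl ester or a primary amide.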